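A chloro-bearing pyridyl amide weighed against three measured analogues

The source may report more compounds than this note shows. Statements on the series, on what has been measured and on what is new or still open speak of the compounds shown alone.

Compound 3 `COc1ccc(C(=O)Nc2cccnc2)cc1OC1CCCC1` carries a pyridin-3-yl group on the amide nitrogen of the shared core. Among the measured compounds shown here, in an assay on isolated protein for inhibition of phosphodiesterase 4A (Sus scrofa) (a lower number here means a stronger inhibitor, a higher number a weaker inhibitor), compound 3 gives 550 nM, the highest of the three numbers known so far. Compound 1 `COc1ccc(C(=O)Nc2ccccc2C)cc1OC1CCCC1` gives 300 nM, so that a 1.8-fold higher number from compound 1 to compound 3 (0.26 log units; within the scatter); compound 2 `COc1ccc(C(=O)Nc2c(C)cccc2Cl)cc1OC1CCCC1` gives 100 nM, so that a 5.5-fold higher number from compound 2 to compound 3 (0.74 log units; beyond the scatter). Compound 4 `COc1ccc(C(=O)Nc2ccncc2Cl)cc1OC1CCCC1` differs from compound 3 by 3-chloropyridin-4-yl in place of pyridin-3-yl on an amide-type nitrogen. The measured step that bears on this is the one in which a chloro entered an aromatic carbon: a 3.0-fold lower number from compound 1 to compound 2 (0.48 log units; beyond the scatter). For the measured compounds named here, no measured pair compares pyridin-4-yl with pyridin-3-yl. Because a 3.0-fold lower number from compound 1 to compound 2 (0.48 log units; beyond the scatter) was modest, compound 4 is expected to give a somewhat lower number, a 1.8-fold lower number from compound 3 to compound 4 (0.26 log units; within the scatter), with an estimate of 300 nM ranging from 120 nM to 800 nM.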

Compound 4, half-maximal inhibitory concentration: 16 nM
Compound 4: the middle estimate sits 19-fold (1.27 log units) above what was measured, and the stated range ends above it.
By their numbers in this assay, from the lowest: compound 4; then compound 2; then compounds 1 and 3 (each within the scatter of the next).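

In this assay, among the compounds shown here, the amide-type nitrogen proved far more sensitive to its substituent than the earlier compounds showed, with 3-chloropyridin-4-yl in place of pyridin-3-yl giving a 34-fold lower number from compound 3 to compound 4 (1.54 log units; beyond the scatter) as the largest step so far. A pyridine ring here also outdoes both substituted phenyl groups, in a 19-fold lower number from compound 1 to compound 4 (1.27 log units; beyond the scatter) and in a 6.3-fold lower number from compound 2 to compound 4 (0.80 log units; beyond the scatter) as well. Nothing in the available evidence accounts for this gain. The compounds shown do not separate the chloro from the change from pyridin-3-yl to a pyridin-4-yl attachment. On these data alone, how an unsubstituted pyridin-4-yl would read remains open, as does a bromo or an amine in place of the chloro.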